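The compounds below may be only part of what the source reports. "The series", "measured", "known", "first", "only" and "open" are said of these compounds alone.

Of the compounds shown here, two have been measured. Within the data shown here, in a functional assay on L1210 cells (Mus musculus), with a stated time of 1 days (on this read-out higher numbers stand for higher potency (the scale is a negative logarithm) and lower numbers for lower potency), compound 1 `CC1=C(N2CC2)C(=O)C(CCCOC(N)=O)=C(N2CC2)C1=O` gives 5.55, while compound 2 `CC1=C(N2CC2)C(=O)C(CCC(=O)N(C)C)=C(N2CC2)C1=O` gives 5.09; the single step, a number 0.46 log units lower from compound 1 to compound 2 (beyond the scatter), leaves compound 2 the lower of the two. Compound 3 `CC1=C(N2CC2)C(=O)C(N2CC2)=C(N2CC2)C1=O` differs from compound 2 by aziridin-1-yl in place of 2-(dimethylcarbamoyl)ethyl on a double-bonded ring carbon. Among the measured compounds shown here, no measured step bears on this change: the one known step concerns a different exchange on the chain, so a shift of either direction cannot be ruled out. Compound 3 is therefore tentatively expected to lie near compound 2, at 5.6 within 4.8 to 6.6, a step of a number 0.51 log units higher from compound 2 to compound 3 (beyond the scatter).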

Compound 3, logarithm of the reciprocal of the active concentration, log(1/C): 6.54
For compound 3 the middle estimate is 0.94 log units below the measured one; low and high end bracket the measured number.
By their numbers in this assay, from the lowest: compound 2; then compound 1; then compound 3.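

At this double-bonded ring carbon, the earlier exchange within the chain gave only a modest step, whereas aziridin-1-yl in place of the whole 2-(dimethylcarbamoyl)ethyl chain moves the value much further in this assay (a number 1.45 log units higher from compound 2 to compound 3 (beyond the scatter)). Measured against the other chain, the same group again gives a rise (a number 0.99 log units higher from compound 1 to compound 3 (beyond the scatter)), so compound 3 stands above both chain-bearing compounds. Nothing available explains this rise. From the compounds shown here alone, whether it requires the three-membered ring stays open: a dimethylamino group, a pyrrolidine ring or a plain methyl group on this carbon would address that.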